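Cytotoxicity notes on an aryl urea series

The compounds below may be only part of what the source reports. "The series", "measured", "known", "first", "only" and "open" are said of these compounds alone.

Compound 1 `Cc1cc(NC(=O)Nc2ccccc2F)c2ccccc2n1`: > 25000 nM
Compound 2 `CSc1ccccc1NC(=O)Nc1cc(C)nc2ccccc12`: > 25000 nM

In an ADME assay on BJ cells (Homo sapiens) for cytotoxicity, with a stated time of 72 h (a lower number here means that less compound is needed, a higher number that more compound is needed for the effect), compound 1 gives only a limit, > 25000 nM. In this assay compound 2 likewise gives only a limit, > 25000 nM. The step that the two limits leave unreadable from compound 1 to compound 2 stays unreadable because the limit of > 25000 nM in this assay, at which 2 of the 2 values shown sit, holds both values. Compound 3 `Cc1cc(NC(=O)Nc2ccccc2OC(F)(F)F)c2ccccc2n1` carries trifluoromethoxy in place of methylsulfanyl on an aromatic carbon. For the measured compounds named here, no measured step bears readably on this change, so no size beyond the scatter can be foreseen in this assay in either direction. Compound 3 is expected to give 40000 nM, with a range from 15000 nM to 100000 nM, which would mean an estimated step that the limit leaves unreadable from compound 2 to compound 3.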

Compound 3, half-maximal effective concentration in the BJ assay: > 25000 nM
Compound 3 was reported as a limit; the forecaster's own chance of this, stated with the estimate: 85%; the middle value is on the limit's open side.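

No step can be read among compound 1, compound 2 and compound 3 in the BJ assay, because all three sit at the same limit: the limit of > 25000 nM in the BJ assay, at which 3 of the 3 values shown sit.

In a physicochemical assay for solubility, at pH 7.4 (on this read-out lower numbers stand for lower solubility and higher numbers for higher solubility), compound 2 gives 21000 nM and compound 3 gives 4600 nM.

The compounds shown leave open how these three compare in the BJ assay at any measured value.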